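The compounds below may be only part of what the source reports. "The series", "measured", "known", "first", "only" and "open" are said of these compounds alone.

Measured so far:
- compound 1 `O=[N+]([O-])c1cccc(CNc2cc(Br)cc3[nH]ncc23)c1` gives 95% in an assay for inhibition of Indoleamine 2,3-dioxygenase 1 (Homo sapiens), with stated times of 10 min and 60 min, tested at 100 uM; on this read-out lower numbers stand for a weaker effect and higher numbers for a stronger effect at the one concentration tested
- compound 2 `O=[N+]([O-])c1cccc(CNc2cc(C(F)(F)F)cc3[nH]ncc23)c1` gives 69%
- compound 3 `NCCn1ncc2c(NCc3ccccc3[N+](=O)[O-])cc(C(F)(F)F)cc21` gives 30%

Compound 2 stands second of the three numbers in this assay: compound 1 lies above it, with a number 26 percentage points lower from compound 1 to compound 2 (beyond the scatter) marking the drop when going to compound 2; compound 3 lies well below both, though compound 3 differs from compound 2 in more than one place, so only its number is noted here.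

Compound 4 `FC(F)(F)c1cccc(CNc2cc(C(F)(F)F)cc3[nH]ncc23)c1` is the next member and is still to be measured. It differs from compound 2 as follows: trifluoromethyl in place of nitro on an aromatic carbon. Going by the values given here, no measured step changes the nitro group on this ring, so there is no direct precedent. Among the compounds with values here, the only step on record, the trifluoromethyl in place of bromo on the core, a number 26 percentage points lower from compound 1 to compound 2 (beyond the scatter), lowered the read-out beyond the scatter; this concerns a different ring and serves only as a loose guide to how sensitive the series is to such swaps.

The expectation for compound 4 is a decrease beyond the scatter, of about a number 21 percentage points lower from compound 2 to compound 4 (beyond the scatter). Compound 4 is therefore estimated at 48%, with a range from 22% to 72%.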

Compound 4, a percentage reported as inhibition, at one concentration (the size of the read-out at that concentration, not a potency): 49%
Compound 4: the middle estimate sits 1 percentage points below what was measured; the range from low to high includes it.
By their numbers in this assay, from the lowest: compound 3; then compound 4; then compound 2; then compound 1.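

Going by these compounds alone, replacing nitro with trifluoromethyl on the six-membered aromatic ring of carbon only, meta to a large group, gives in this assay a number 20 percentage points lower from compound 2 to compound 4 (beyond the scatter), the first measured step at this position and one that shows the read-out depends on this substituent as well as on the group changed on the core. The nitro group is not required for a read-out at the one concentration tested, since compound 4, which carries trifluoromethyl here and no nitro, still gives 49% and so keeps a clear effect, although this single-concentration number is not a potency. No measured data available here bear on the reason for the fall in the read-out with this swap.

Going by these compounds, it remains open whether an amine, a carboxylic acid or a nitrile at this position would keep the read-out nearer that of compound 2, and whether the same swap would have a similar effect with bromo on the core. Compound 3 differs from compound 2 in more than one place and therefore cannot settle either question.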